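The source may report more compounds than this note shows. Statements on the series, on what has been measured and on what is new or still open speak of the compounds shown alone.

Compound 2 `CC#C[C@@H](CC(=O)O)c1ccc(OC[C@H]2COc3ccc(OC(F)(F)F)cc3O2)cc1` stands highest of the two compounds measured in a functional assay on HEK293 cells for agonist activity at Free fatty acid receptor 1 (Homo sapiens), read by fluorescence and calcium flux, with a stated time of 10 min (on this read-out higher numbers stand for an effect only at larger amounts of compound and lower numbers for an effect already at smaller amounts), where compound 2 gives 700 nM. Going by the values given here, its nearest neighbour, compound 1 `CC#C[C@@H](CC(=O)O)c1ccc(OC[C@H]2COc3ccc(Cl)cc3O2)cc1`, gives 50 nM in this assay; the only step at hand, a 14-fold higher number from compound 1 to compound 2 (1.15 log units; beyond the scatter), is large. Compound 3 `CC#C[C@@H](CC(=O)O)c1ccc(OC[C@H]2COc3ccc(CO)cc3O2)cc1` differs from compound 2 by hydroxymethyl in place of trifluoromethoxy on an aromatic carbon. Among the compounds with values here, no measured step concerns a hydroxymethyl, so the direction of this change is open; the one known step shows only that exchanges at this place can shift the numbers strongly. Compound 3 is therefore expected to lie between the two measured compounds, at an estimated 300 nM (range 60 nM to 1500 nM), a step of a 2.3-fold lower number from compound 2 to compound 3 (0.37 log units; beyond the scatter).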

Compound 3, half-maximal effective concentration: > 30000 nM
Compound 3: a limit, no number; the forecaster's own chance of this, stated with the estimate: 5%; at least 100-fold (2.00 log units) between middle value and limit.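

In this assay compound 3 gives only a limit of the assay, > 30000 nM, and no number. Even so, the change to hydroxymethyl is large in both comparisons, with an at least 42-fold higher number from compound 2 to compound 3 (1.63 log units; beyond the scatter) and an at least 600-fold higher number from compound 1 to compound 3 (2.77 log units; beyond the scatter), so this position is far less forgiving than the single earlier step could show. Hydroxymethyl also brings a hydrogen-bond donor where trifluoromethoxy has none. Going by these compounds, whether the donor matters here, or the exchange of groups as a whole, stays open, as does how a methoxy or an amine would read at this place.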